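The source may report more compounds than this note shows. Statements on the series, on what has been measured and on what is new or still open speak of the compounds shown alone.

Measured so far in a functional assay on HepG2 cells (Homo sapiens) for antiproliferative activity, read by MTT assay, with a stated time of 48 h; on this read-out lower numbers stand for stronger inhibition and higher numbers for weaker inhibition:
Compound 1 `Cc1cccc(-n2nncc2CN2C(=O)C3(C(C#N)=C(N)Oc4c3c3nc5ccccc5nc3c3ccccc43)c3ccccc32)c1` gives > 50000 nM, which is a limit of the assay.
Compound 2 `N#CC1=C(N)Oc2c(c3nc4ccccc4nc3c3ccccc23)C12C(=O)N(Cc1cnnn1-c1cccc(Cl)c1)c1ccccc12` gives > 50000 nM, likewise a limit.
Compound 3 `N#CC1=C(N)Oc2c(c3nc4ccccc4nc3c3ccccc23)C12C(=O)N(Cc1cnnn1-c1cccc(S(N)(=O)=O)c1)c1ccccc12` gives 21500 nM.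

Among the measured compounds shown here, compound 3 thus stands alone with the only number among the three; the other two values sit at the limit of > 50000 nM in this assay, at which 2 of the 3 values shown sit. For the measured compounds named here, the steps that bear on what follows are an at least 2.3-fold lower number from compound 1 to compound 3 (0.36 log units; beyond the scatter) and an at least 2.3-fold lower number from compound 2 to compound 3 (0.36 log units; beyond the scatter), both at least modest and both toward a lower number when sulfamoyl enters. The step that the two limits leave unreadable from compound 1 to compound 2 lies between two limits and its size cannot be read.

Compound 4 `Cc1ccc(-n2nncc2CN2C(=O)C3(C(C#N)=C(N)Oc4c3c3nc5ccccc5nc3c3ccccc43)c3ccccc32)c(C)c1` carries the change (2,4-dimethylphenyl in place of 3-sulfamoylphenyl on an aromatic nitrogen). This removes the sulfamoyl that set compound 3 apart and brings in methyl groups, of the kind borne by compound 1. Compound 4 is therefore expected to fall back toward compound 1, whose result in this assay is > 50000 nM. Compound 4 is estimated at 65000 nM, with a range from 25000 nM to 200000 nM, most likely reported again as a limit. The expected step of a 3.0-fold higher number from compound 3 to compound 4 (0.48 log units; beyond the scatter) would undo the gain that sulfamoyl brought.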

Compound 4, half-maximal inhibitory concentration: > 50000 nM
Compound 4 gave a limit, no number; the forecaster's own chance of this, stated with the estimate: 70%; the middle value does not contradict the limit.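

In this assay, among the compounds shown here, exchanging the 3-sulfamoylphenyl on the aromatic nitrogen for 2,4-dimethylphenyl gives an at least 2.3-fold higher number from compound 3 to compound 4 (0.36 log units; beyond the scatter), so the number seen for compound 3 is lost with a second kind of aryl group, one that carries two methyl groups rather than the single methyl of compound 1 or the single chloro of compound 2. Compound 4 gives > 50000 nM, which is a limit and not a number, so the steps linking it to compound 1 and compound 2 cannot be read, and nothing separates these three compounds from one another. Among the four compounds, only compound 3, the one bearing sulfamoyl, stands clear of the value the others share: the limit of > 50000 nM in this assay, at which 3 of the 4 values shown sit.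

The compounds shown leave open whether a number at this position needs the whole sulfamoyl group or would also appear with an amine, a carboxylic acid or a methylsulfonyl group on the phenyl ring in its place. They also leave open how the sulfamoyl group would fare on a phenyl ring with a methyl group alongside it, as in the 2,4-dimethylphenyl of compound 4.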